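Moving a halogen around the aryl group on the tetrazole nitrogen

A few compounds are considered here, and "the series" means these few. Any claim that something is new, unique, unknown or untested is made for them only; others in the source may bear on it.

Measured compounds:
Compound 1 `COc1ccc(Nc2nnnn2-c2ccc(Br)cc2)cc1`: 125000 nM
Compound 2 `COc1ccc(-n2nnnc2Nc2ccccc2Cl)cc1`: 246000 nM
Compound 3 `COc1ccc(Nc2nnnn2-c2ccccc2Br)cc1`: 119000 nM

All three were tested in an ADME assay on V79 cells (Cricetulus griseus) for cytotoxicity, read by MTT assay, with a stated time of 72 h; on this read-out lower numbers stand for stronger inhibition and higher numbers for weaker inhibition. Compound 2 shows the highest of the three numbers, yet its gap to compound 1 falls within the usual scatter; only compound 3 lies beyond it. Among the measured pairs, one step speaks to the present question: a 1.1-fold lower number from compound 1 to compound 3 (0.02 log units; within the scatter). Shifting the bromine from one position of the phenyl ring to another left the number essentially unchanged.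

The unmeasured compound 4 `COc1ccc(-n2nnnc2Nc2cccc(Br)c2)cc1` differs from compound 2 as follows: 3-bromophenyl in place of 2-chlorophenyl on a nitrogen on an aromatic ring. This change both swaps chlorine for bromine and moves the halogen to a different position on the ring. Going by the values given here, the only comparable step, from compound 1 to compound 3, stayed within the scatter, and no measured pair compares chlorine with bromine. Given that, no step beyond the scatter is expected for this assay, in either direction. The estimate therefore is that compound 4 gives 200000 nM, with a range of 100000 nM to 400000 nM, corresponding to an expected step of a 1.2-fold lower number from compound 2 to compound 4 (0.09 log units; within the scatter).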

Compound 4, half-maximal inhibitory concentration: 241000 nM
The estimate for compound 4 lay 1.2-fold (0.08 log units) below the measured number; the measured number falls inside the stated range.
By their numbers in this assay, from the lowest: compounds 3, 1, 4 and 2 (each within the scatter of the next, the first and the last beyond it).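

In this assay, exchanging 2-chlorophenyl for 3-bromophenyl gives a 1.0-fold lower number from compound 2 to compound 4 (0.01 log units; within the scatter) and so stays within the scatter, even though the halogen and its place on the ring differ at the same time. Going by these compounds alone, the earlier step, a 1.1-fold lower number from compound 1 to compound 3 (0.02 log units; within the scatter), only moved a bromine around its ring, so this is the first pair in which chlorine gives way to bromine, and here too the size of the step is no larger than repeated measurements of this kind would produce. Across this one pair, then, the read-out does not distinguish the 2-chlorophenyl group from the 3-bromophenyl group, and no measurement at hand offers a reason for that.

With two features altered in a single step, the separate contributions of the halogen's identity and of its place on the ring remain unresolved, and a larger effect from one could in principle be offset by the other. It also remains open whether a phenyl ring carrying an amine or a carboxylic acid in place of the halogen would stay within the scatter of these compounds.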